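This account rests on a few compounds, and the source may have more. Where it says the series, first, only, none or still open, it means among the compounds named here.

Compound 1 `CCCCc1c(F)c(N)c2c(=O)cc(-c3ccc(N)c(F)c3)oc2c1F` and compound 2 `Nc1ccc(-c2cc(=O)c3c(N)c(F)c(Br)c(F)c3o2)cc1F` share one core. In a functional assay on MCF7 cells (Homo sapiens) for cytotoxicity, read by neutral red uptake, with a stated time of 3 days (a lower number here means a stronger inhibitor, a higher number a weaker inhibitor), compound 1 gives 8800 nM, while compound 2 gives 160 nM, the lowest of the two numbers; the step of a 55-fold lower number from compound 1 to compound 2 (1.74 log units; beyond the scatter) is large. Compound 3 `COc1c(F)c(N)c2c(=O)cc(-c3ccc(N)c(F)c3)oc2c1F` differs from compound 2 by methoxy in place of bromo on an aromatic carbon. For the measured compounds named here, no measured step covers a methoxy group; the one measured step shows a large change at the same position, so a sizeable step is expected here too, though its direction is uncertain. The expected step is a 6.3-fold higher number from compound 2 to compound 3 (0.80 log units; beyond the scatter), and compound 3 is estimated at 1000 nM with a range of 200 nM to 5000 nM.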

Compound 3, half-maximal inhibitory concentration: 100 nM
Beside the measured number, compound 3's estimate is 10-fold (1.00 log units) above it; the whole stated range lies above it.
By their numbers in this assay, from the lowest: compounds 3 and 2 (each within the scatter of the next); then compound 1.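

In this assay the change to methoxy gives a 1.6-fold lower number from compound 2 to compound 3 (0.20 log units; within the scatter) even though methoxy carries a hydrogen-bond acceptor and bromo none, so these two different groups read alike at this position. Among the three compounds, butyl alone stands apart: methoxy in its place gives an 88-fold lower number from compound 1 to compound 3 (1.94 log units; beyond the scatter) and so repeats the large step seen with bromo. Nothing measured here explains these results. The compounds shown leave open how an amine, a hydroxyl group or a shorter chain such as ethyl would read at this position.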